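Acetyl to isopropylcarbonyl on a stable amide scaffold

The source may report more compounds than this note shows. Statements on the series, on what has been measured and on what is new or still open speak of the compounds shown alone.

Compound 1 `CC(=O)N1CC2(CC(NC(=O)c3cc(-c4ccc(F)cc4)no3)C2)C1`: 84%
Compound 2 `CC(=O)N1CC2(CC(NC(=O)c3cc(-c4ccccc4)no3)C2)C1`: > 100%

In an ADME assay on microsomes from liver (Homo sapiens) for metabolic stability, with a stated time of 0.5 h, tested at 0.5 mg/mL (a lower number here means that less of the compound is left, a higher number that more of the compound is left), compound 1 gives 84%. The value of compound 2, > 100%, is a limit of the assay and not a number (the limit of > 100% in this assay, at which 1 of the 2 values shown sits). For the measured compounds named here, the one measured step, a number at least 16 percentage points higher from compound 1 to compound 2 (beyond the scatter), concerns a fluoro on an aromatic carbon and not the carbonyl carbon. Compound 3 `CC(C)C(=O)N1CC2(CC(NC(=O)c3cc(-c4ccccc4)no3)C2)C1` differs from compound 2 by isopropyl in place of methyl on a carbonyl carbon. Going by the values given here, no measured step changes this carbonyl substituent, so the direction is open; the expected step of a number at least 8 percentage points lower from compound 2 to compound 3 (that floor lies within the scatter) is small. Compound 3 is estimated at 92%, between 72% and 100%.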

Compound 3, percent of the compound remaining: 79%
Compound 3: the middle estimate sits 13 percentage points above what was measured, and the stated range covers the measured number.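

Isopropyl in place of methyl on the carbonyl carbon gives a number at least 21 percentage points lower from compound 2 to compound 3 (beyond the scatter), so this position, which no earlier step touched, does bear on how much compound is left. Alongside the aromatic fluoro step, it is a second place where a single change moves the number beyond the scatter. Compound 2 gives > 100%, a limit of the assay and not a number, so this step has only a floor: the limit of > 100% in this assay, at which 1 of the 3 values shown sits.

The compounds shown cannot separate size from branching, which an ethyl or straight propyl group on this carbonyl carbon would test. As far as these compounds go, whether isopropyl has the same effect alongside the aromatic fluoro also stays open.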